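Series notes: aryl swap at the bicyclic core of compound 1

The source may hold more compounds than are shown below. What is called first, only, known or untested is meant among the compounds shown, and "the series" means these compounds.

The series holds three measured compounds built on one shared core. Compound 1 `COc1cc(-c2ccnc3cc(-c4ccc5ccn(C)c5c4)nn23)cc(OC)c1OC` gives 657 nM in a functional assay on B16-F0 cells (Mus musculus) for inhibition, read by CCK-8 assay, with a stated time of 48 h; a lower number here means a stronger inhibitor, a higher number a weaker inhibitor. Compound 2 `COc1cc(-c2ccnc3cc(-c4cn(C(=O)OC(C)(C)C)c5ccccc45)nn23)cc(OC)c1OC` gives 3070 nM, and compound 3 `COc1cc(-c2ccnc3cc(-c4cn(CO)c5ccccc45)nn23)cc(OC)c1OC` gives 93 nM. On these numbers compound 1 stands second highest of three: compound 2 sits at a higher number than compound 1, and compound 3 at a lower number than compound 1, both gaps beyond the scatter.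

Going by the values given here, the one step measured within a single change is a 33-fold lower number from compound 2 to compound 3 (1.52 log units; beyond the scatter), a large shift brought about by exchange of the substituent on the indole nitrogen.

Compound 4 `COc1cc(-c2ccnc3cc(-c4ccc(C(F)(F)F)cc4)nn23)cc(OC)c1OC` has not been measured. It differs from compound 1 by 4-(trifluoromethyl)phenyl in place of 1-methyl-1H-indol-6-yl on an aromatic carbon. Among the compounds with values here, no measured step bears on this kind of change: the step from compound 2 to compound 3 concerns only the substituent on the indole nitrogen, while here the whole indole is replaced. The three measured values show that this position tolerates wide swings. With nothing to anchor a direction, compound 4 is expected to give a number near that of compound 1, the step of a 1.4-fold higher number from compound 1 to compound 4 (0.14 log units; within the scatter) being the estimate. Compound 4 is therefore estimated at 900 nM, within a range of 250 nM to 3500 nM.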

Compound 4, half-maximal inhibitory concentration: 1770 nM
Beside the measured number, compound 4's estimate is 2.0-fold (0.29 log units) below it, and the stated range covers the measured number.
By their numbers in this assay, from the lowest: compound 3; then compound 1; then compounds 4 and 2 (each within the scatter of the next).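

Exchanging 1-methyl-1H-indol-6-yl for 4-(trifluoromethyl)phenyl on the aromatic carbon gives, in this assay, a 2.7-fold higher number from compound 1 to compound 4 (0.43 log units; beyond the scatter), the first measured replacement of the whole aryl group at this place. The indole is therefore not indispensable here: a group with one six-membered aromatic ring of carbon only and no fused five-membered ring still gives a finite inhibitory value, and the shift is much smaller than a 33-fold lower number from compound 2 to compound 3 (1.52 log units; beyond the scatter) seen on changing only the substituent on the indole nitrogen. No available measurement accounts for the upward shift.

Going by these compounds alone, the single step changes the ring system and brings in trifluoromethyl together, so it leaves open how much of the shift belongs to losing the indole and how much to the trifluoromethyl group, a question that plain phenyl, 4-methoxyphenyl or 4-aminophenyl at the same place would help to separate. Going by these compounds, it is also open whether hydroxymethyl in place of the methyl on the nitrogen of compound 1 would lower the number as it does in the step to compound 3.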